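A few compounds are considered here, and "the series" means these few. Any claim that something is new, unique, unknown or untested is made for them only; others in the source may bear on it.

Three compounds in this set share one core and differ only in the chain attached to the nitrogen on that core. Compound 1 `COc1ccc2c(c1)[n+]([O-])nc(NCOCc1ccccc1)[n+]2[O-]` gives 1190 nM in a functional assay on SMMC-7721 cells (Homo sapiens) for cytotoxicity, read by MTT assay, with a stated time of 72 h; on this read-out higher numbers stand for weaker inhibition and lower numbers for stronger inhibition. Compound 3 `[O-][n+]1nc(NCOCc2ccc(C(F)(F)F)cc2)[n+]([O-])c2ccccc21` gives 780 nM in this assay. Compound 2 `CCCCCOCNc1n[n+]([O-])c2ccccc2[n+]1[O-]` gives 3050 nM in this assay, the highest of the three numbers, so it is the weakest inhibitor here: compound 1 lies nearest to it and compound 3 furthest, and both of those gaps are larger than the usual scatter of repeated measurements.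

The next compound, compound 4 `CCOCNc1n[n+]([O-])c2ccccc2[n+]1[O-]`, is made from compound 2 by one change: hydrogen in place of propyl on a saturated chain carbon, two bonds along the chain from an oxygen on a saturated carbon. For the measured compounds named here, no pair of measured compounds shows this kind of shortening of a chain, so there is no directly comparable step to lean on. The step of a 1.1-fold higher number from compound 2 to compound 4 (0.06 log units; within the scatter) is expected to be small, probably not beyond the scatter. Compound 4 is therefore expected to give about 3500 nM, with a range from 1500 nM to 8500 nM.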

Compound 4, half-maximal inhibitory concentration: 4230 nM
Compound 4: middle estimate off by 1.2-fold (0.08 log units), on the low side; the measured number falls inside the stated range.
By their numbers in this assay, from the lowest: compounds 3 and 1 (each within the scatter of the next); then compounds 2 and 4 (each within the scatter of the next).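

For the compounds shown here, compound 2 and compound 4 are the first pair in this set that differ in one place, so the effect of chain length can now be read directly. In this assay, going from pentyloxy to ethoxy gives a 1.4-fold higher number from compound 2 to compound 4 (0.14 log units; within the scatter) and so leaves the read-out within the usual scatter. At this position, on a saturated chain carbon two bonds along the chain from an oxygen on a saturated carbon, removing propyl therefore makes no clear difference in this pair, and no measurement shown here offers an explanation for that result.

Two chain lengths cannot establish a trend, so a longer chain such as octyloxy might or might not behave in the same way. As far as these compounds go, whether an amine or a carboxylic acid at the end of the chain would shift the number also remains open.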